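Chloro to Methoxy: Expecting the Next Result for Compound 4

The source may report more compounds than this note shows. Statements on the series, on what has been measured and on what is new or still open speak of the compounds shown alone.

The study covers three measured compounds and one awaiting its number. Compound 1 `CC(Br)C(=O)Nc1ccc(C(=O)/C=C/c2ccc(Cl)cc2)cc1` gives 39% in a functional assay on the whole organism (strain albino) for inhibition, with Rattus norvegicus as the target, read by paw edema, with stated times of 30 min and 1 h, at a dose of 100 mg/kg by the oral route; on this read-out lower numbers stand for less inhibition and higher numbers for more inhibition at the one dose given (going by the name of the read-out). Compound 2 `COc1ccc(/C=C/C(=O)c2ccc(NC(=O)C(C)Br)cc2)cc1` gives 39% in this assay. Compound 3 `CC(=O)c1ccc(OCC(=O)Nc2ccc(C(=O)/C=C/c3ccc(Cl)cc3)cc2)cc1` gives 43% in this assay; this is the highest of the three numbers, but its gaps to compound 1 and to compound 2 both lie within the usual scatter, so no ranking among the three can be drawn from them.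

One structural change has already been tested directly. Compound 2 differs from compound 1 by methoxy in place of chloro on an aromatic carbon, and the result was no change at the digits printed from compound 1 to compound 2 (within the scatter).

Compound 4 `COc1ccc(/C=C/C(=O)c2ccc(NC(=O)COc3ccc(C(C)=O)cc3)cc2)cc1` has not yet been measured in this assay. It differs from compound 3 by methoxy in place of chloro on an aromatic carbon; the place is described in the same words as for the measured pair, so this is the same change made once more, on a different core. The difference between the core of compound 1 and the core of compound 3 is not broken down here.

Because no change at the digits printed from compound 1 to compound 2 (within the scatter), the same change on compound 3 is expected to leave the read-out essentially where compound 3 stands. Compound 4 is therefore expected to give about 43% in this assay, with a likely range from 33% to 53%. Among the measured compounds shown here, the step this estimate means, no change at the digits printed from compound 3 to compound 4 (within the scatter), is expected to be small, resting on the single measured pair rather than on any broader pattern.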

Compound 4, a percentage reported as inhibition, in the whole organism at one dose (the size of the read-out at that dose, not a potency): 28%
Estimate against measurement, compound 4: 15 percentage points above, outside the stated range (below it).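

Methoxy in place of chloro on an aromatic carbon, when carried to a second core, gave a number 15 percentage points lower from compound 3 to compound 4 (beyond the scatter) in this assay. The outcome of this change therefore did not carry over unchanged from one core to the other in this series, and a neutral result on one core could not be taken as a guide to the other: the same change on two cores in this assay, no change at the digits printed (within the scatter) from compound 1 to compound 2 and a number 15 percentage points lower (beyond the scatter) from compound 3 to compound 4, 15 percentage points apart, beyond the scatter of two such steps

Among the compounds shown here, this does not show which part of the cores separates the two results, since they differ by more than one feature and that difference is not broken down, and with only two pairs, read at a single dose, it gives no general rule for the direction or size of the step on any further core.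

The compounds shown leave open whether a fluoro or a methyl group in the same place, para to a large group, would follow the methoxy result on each of the two cores. They also leave open whether an amine or a carboxylic acid in place of the bromo of compound 1 or the acetyl of compound 3 would alter how the change from chloro to methoxy reads in this assay.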